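Replacing the phenyl group of compound 2

The source may hold more compounds than are shown below. What is called first, only, known or untested is meant among the compounds shown, and "the series" means these compounds.

Among the compounds with values here, in a functional assay, read by spectrophotometry, with a stated time of 30 min (a higher number here means that more compound is needed for the effect, a lower number that less compound is needed), compound 1 `COc1ccc(C(=O)OCC2Oc3ccc([C@H]4Oc5cc(O)cc(O)c5C(=O)[C@@H]4O)cc3OC2c2ccc(O)c(OC)c2)cc1` gives 73300 nM and compound 2 `COc1cc(C2Oc3cc([C@H]4Oc5cc(O)cc(O)c5C(=O)[C@@H]4O)ccc3OC2COC(=O)c2ccccc2)ccc1O` gives 105000 nM so compound 2 lies within the scatter of the only other measured compound. Compound 3 `COc1cc(C2Oc3cc([C@H]4Oc5cc(O)cc(O)c5C(=O)[C@@H]4O)ccc3OC2COC(=O)c2cc(N)cc([N+](=O)[O-])c2)ccc1O` keeps the core of compound 2 and differs in one place, with 3-amino-5-nitrophenyl in place of phenyl on a carbonyl carbon. Within the data shown here, the only measured step, hydrogen in place of methoxy on an aromatic carbon, is a 1.4-fold higher number from compound 1 to compound 2 (0.16 log units; within the scatter) and it leaves this group untouched. Among the measured compounds shown here, no measured compound varies the group, so the data offer no size or direction for the change. In this assay the estimated step is a 1.2-fold lower number from compound 2 to compound 3 (0.07 log units; within the scatter) which means that no move beyond the scatter is expected. The estimate for compound 3 is 90000 nM with 35000 nM to 230000 nM as the expected range.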

Compound 3, half-maximal effective concentration: > 300000 nM
Compound 3 ended at the assay's limit; the forecaster's own chance of this, stated with the estimate: 15%; middle value at least 3.3-fold (0.52 log units) from the limit.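

Compound 3 gives no number in this assay, only a limit: the limit of > 300000 nM in this assay, at which 1 of the 3 values shown sits. Even so, the group on a carbonyl carbon proves able to move the result: 3-amino-5-nitrophenyl in place of phenyl gives an at least 2.8-fold higher number from compound 2 to compound 3 (0.45 log units; beyond the scatter), and in place of 4-methoxyphenyl it gives an at least 4.0-fold higher number from compound 1 to compound 3 (0.61 log units; beyond the scatter). Both steps lie beyond the scatter and point towards more compound being needed, whereas the earlier step between compound 1 and compound 2 stayed within it and so showed nothing about this position.

As far as these compounds go, the true size of both steps stays open, since the limit bounds them on one side only. Also open, from the compounds shown here alone, is whether the amine alone, the nitro group alone, or a different group here, such as a carboxylic acid or a cyclohexyl ring, would shift the number in the same direction.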